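Ethoxy in place of methyl: an estimate for compound 4

The source may report more compounds than this note shows. Statements on the series, on what has been measured and on what is new or still open speak of the compounds shown alone.

Three compounds share one core and differ only in the group on an aromatic carbon. In an assay for binding affinity to adenosine receptor A1 (Bos taurus) (on this read-out lower numbers stand for stronger inhibition and higher numbers for weaker inhibition), compound 1 `Cn1c(=O)c2nc(-c3ccc(F)cc3)[nH]c2n(C)c1=O` gives 3.5 nM, compound 2 `CN(C)c1ccc(-c2nc3c(=O)n(C)c(=O)n(C)c3[nH]2)cc1` gives 1.8 nM, and compound 3 `Cc1ccc(-c2nc3c(=O)n(C)c(=O)n(C)c3[nH]2)cc1` gives 0.8 nM, the lowest of the three and the strongest binder among them. Compound 4 `CCOc1ccc(-c2nc3c(=O)n(C)c(=O)n(C)c3[nH]2)cc1` alters compound 3 at that same place: ethoxy in place of methyl on an aromatic carbon. For the measured compounds named here, no measured step introduces ethoxy. The nearest comparison is a 2.3-fold lower number from compound 2 to compound 3 (0.35 log units; beyond the scatter), where methyl replaced a group containing a hydrogen-bond acceptor; a 4.4-fold lower number from compound 1 to compound 3 (0.64 log units; beyond the scatter) and a 1.9-fold lower number from compound 1 to compound 2 (0.29 log units; within the scatter) are the other steps seen. Reversing that direction, a small rise is expected, a 2.0-fold higher number from compound 3 to compound 4 (0.30 log units; within the scatter). Compound 4 is therefore estimated at 1.6 nM, within 0.5 nM to 5 nM.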

Compound 4, half-maximal inhibitory concentration: 2 nM
For compound 4 the middle estimate is 1.3-fold (0.10 log units) below the measured one, within the range that was stated.
By their numbers in this assay, from the lowest: compound 3; then compounds 2, 4 and 1 (each within the scatter of the next).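

In this assay, for the compounds shown here, ethoxy, the only group here containing an oxygen, gives a weaker result than methyl at this position (a 2.5-fold higher number from compound 3 to compound 4 (0.40 log units; beyond the scatter)). Ethoxy cannot be told apart from dimethylamino (a 1.1-fold higher number from compound 2 to compound 4 (0.05 log units; within the scatter)) or fluoro (a 1.8-fold lower number from compound 1 to compound 4 (0.24 log units; within the scatter)), so methyl alone stands clear of the other three groups. Nothing available explains this difference. Still open, from the compounds shown here alone, is whether ethyl, which keeps the two-carbon chain without the oxygen, would match methyl or ethoxy. Methoxy and propoxy would show how the result follows the chain length on that oxygen.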